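The source may hold more compounds than are shown below. What is called first, only, known or untested is meant among the compounds shown, and "the series" means these compounds.

Compound 1 `CCOC(=O)c1sc(-c2cccc(NC(=O)c3ccc(C(C)(C)C)cc3)c2)nc1Nc1ccc(N2CCN(C)CC2)cc1` carries an ethoxycarbonyl on its core and a tert-butyl on the benzoyl part. In a functional assay on Raji cells (Homo sapiens) for antiproliferative activity, read by CCK-8 assay, with a stated time of 72 h, tested at 40 uM (a higher number here means more inhibition at the concentration tested (going by the name of the read-out), a lower number less inhibition), compound 1 gives 4.22%. Compound 2 `CCOC(=O)c1sc(-c2cccc(NC(=O)c3ccccc3)c2)nc1Nc1ccc(N2CCN(C)CC2)cc1` differs from it by one change, (hydrogen in place of tert-butyl on an aromatic carbon), and in this assay compound 2 gives 42%; the step of a number 37.8 percentage points higher from compound 1 to compound 2 (beyond the scatter) is the largest among the three measured compounds. Compound 3 `CN1CCN(c2ccc(Nc3nc(-c4cccc(NC(=O)c5ccc(C(C)(C)C)cc5)c4)sc3C(N)=O)cc2)CC1` keeps the tert-butyl, but its core differs from the core of compound 1 by amino in place of ethoxy on a carbonyl carbon. In this assay compound 3 gives 12.1%, and the step of a number 7.9 percentage points higher from compound 1 to compound 3 (within the scatter) shows that the two cores give numbers that cannot be told apart here.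

Compound 4 `CN1CCN(c2ccc(Nc3nc(-c4cccc(NC(=O)c5ccccc5)c4)sc3C(N)=O)cc2)CC1` has not yet been measured in this assay. It differs from compound 3 by hydrogen in place of tert-butyl on an aromatic carbon, the same change as from compound 1 to compound 2, made on an aromatic carbon of a six-membered aromatic ring of carbon only, para to a large group, in both pairs. Because a number 37.8 percentage points higher from compound 1 to compound 2 (beyond the scatter) was large and the two cores gave close numbers, compound 4 is expected to move in the same direction, the estimated step being a number 32.9 percentage points higher from compound 3 to compound 4 (beyond the scatter). Compound 4 is therefore estimated at 45% in this assay, with an expected range from 20% to 70%; a single measured step supports this, and the range is kept wide.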

Compound 4, a percentage reported as inhibition, at one concentration (the size of the read-out at that concentration, not a potency): 91.3%
For compound 4 the middle estimate is 46.3 percentage points below the measured one, and the stated range ends below it.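

In this assay, hydrogen in place of tert-butyl on the core of compound 3 gives a number 79.2 percentage points higher from compound 3 to compound 4 (beyond the scatter), and amino in place of ethoxy on a carbonyl carbon, with no tert-butyl present, gives a number 49.3 percentage points higher from compound 2 to compound 4 (beyond the scatter). The direction of the tert-butyl change therefore carries from one core to the other, but its size does not: the same change on two cores in this assay, a number 37.8 percentage points higher (beyond the scatter) from compound 1 to compound 2 and a number 79.2 percentage points higher (beyond the scatter) from compound 3 to compound 4, 41.4 percentage points apart, beyond the scatter of two such steps. The change on the carbonyl likewise depends on what the benzoyl part carries, so in these four compounds the two changes do not simply add, although a single set of four cannot show why they do not, nor whether the same would hold for other groups: the same change on two cores in this assay, a number 7.9 percentage points higher (within the scatter) from compound 1 to compound 3 and a number 49.3 percentage points higher (beyond the scatter) from compound 2 to compound 4, 41.4 percentage points apart, beyond the scatter of two such steps.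

The compounds shown leave open how a methyl, a methoxy or a chlorine would behave in the place of the tert-butyl, and so whether only the tert-butyl holds the number down or other groups there do as well. On these data alone, they also leave open whether a carboxylic acid or an N-methyl amide on the carbonyl carbon would follow the amino or the ethoxy, and each number here stands for a single concentration, so how the compounds compare in potency also stays unknown.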